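A chain swap on a chloro compound in HeLa cells

The source may report more compounds than this note shows. Statements on the series, on what has been measured and on what is new or still open speak of the compounds shown alone.

Values in a functional assay on HeLa cells (Homo sapiens) for antiproliferative activity, read by MTT assay, with a stated time of 48 h; a higher number here means a weaker inhibitor, a lower number a stronger inhibitor:
Compound 1 `CN(C)CCCn1c(N)c(-c2nc3ccccc3[nH]2)c2nc(C#N)c(C#N)nc21`: 25900 nM
Compound 2 `CCN(CC)CCn1c(N)c(-c2nc3cc(Cl)ccc3[nH]2)c2nc(C#N)c(C#N)nc21`: > 50000 nM
Compound 3 `CN(C)CCCn1c(N)c(-c2nc3cc(Cl)ccc3[nH]2)c2nc(C#N)c(C#N)nc21`: 16500 nM
Compound 4 `CCN(CC)CCCCn1c(N)c(-c2nc3cc(Cl)ccc3[nH]2)c2nc(C#N)c(C#N)nc21`: not yet measured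

Compound 3 stands level with compound 1, as the step shows: a 1.6-fold lower number from compound 1 to compound 3 (0.20 log units; within the scatter). Compound 2 gives > 50000 nM, which is a limit of the assay and not a number. The step measured against that limit is an at least 3.0-fold lower number from compound 2 to compound 3 (0.48 log units; beyond the scatter).

The move to compound 4 is (diethylamino)methyl in place of dimethylamino on a saturated chain carbon, three bonds along the chain from an aromatic nitrogen, that is, 3-(dimethylamino)propyl to 4-(diethylamino)butyl. The chloro group stays, so the chloro step from compound 1 does not bear on it. The nearest guide is compound 2, which also carries diethylamino, with an at least 3.0-fold lower number from compound 2 to compound 3 (0.48 log units; beyond the scatter). Among the measured compounds shown here, that step fixes only a minimum size, and no measured compound carries the 4-(diethylamino)butyl chain. A shift towards a higher number in this assay is therefore expected, though perhaps not one beyond the scatter. The expected step is a 1.5-fold higher number from compound 3 to compound 4 (0.18 log units; within the scatter). For compound 4 the estimated value is 25000 nM, with a range of 9000 nM to 50000 nM.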

Compound 4, half-maximal inhibitory concentration: 3640 nM
Estimate against measurement, compound 4: 6.9-fold (0.84 log units) above; measured number below the stated range.
By their numbers in this assay, from the lowest: compound 4; then compounds 3 and 1 (each within the scatter of the next). At a limit, above all of these: compound 2.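

In this assay, among the compounds shown here, the change from 3-(dimethylamino)propyl to 4-(diethylamino)butyl gives a 4.5-fold lower number from compound 3 to compound 4 (0.66 log units; beyond the scatter), the first step at this position measured between two numbers. Diethylamino at the chain end therefore does not by itself go with a weak result, since the longer chain carrying it gives an at least 13-fold lower number from compound 2 to compound 4 (1.13 log units; beyond the scatter). That step fixes only a minimum, since compound 2 stands at a limit and not at a number: the limit of > 50000 nM in this assay, at which 1 of the 4 values shown sits.

In the step from the 3-(dimethylamino)propyl chain, chain length and the amine change together, so the compounds shown leave open how much of it belongs to each, which a 4-(dimethylamino)butyl chain would help to separate. They also leave open whether a still longer chain, or a piperidine in place of diethylamino, would continue the trend.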